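Methyl on the bridging carbon of compound 3

The source may hold more compounds than are shown below. What is called first, only, known or untested is meant among the compounds shown, and "the series" means these compounds.

Compound 1 `CCc1nc(Cc2c[nH]cn2)c(CC)s1`, compound 2 `CCc1sc(C)nc1Cc1c[nH]cn1` and compound 3 `CCc1nc(CC)c(Cc2c[nH]cn2)s1` have been run in a functional assay on the whole organism (Abdomen) with Mus musculus as the target; a lower number here means that less compound is needed, a higher number that more compound is needed for the effect. In this assay compound 1 gives 1.8 mg/kg. In this assay compound 2 gives 2.3 mg/kg. For compound 3 this assay reports only a limit, > 30 mg/kg, and the limit of > 30 mg/kg in this assay, at which 1 of the 3 values shown sits, records that compound 3 sits at this limit rather than at a number. Compound 2 and compound 1 differ in a single place, (methyl in place of hydrogen on a saturated chain carbon bound to an aromatic carbon), and the measured step is a 1.3-fold lower number from compound 2 to compound 1 (0.11 log units; within the scatter). The difference between the core of compound 2 and the core of compound 3 is not broken down here.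

Compound 4 `CCc1nc(CC)c(C(C)c2c[nH]cn2)s1` is not yet measured in this assay. It differs from compound 3 by methyl in place of hydrogen on a saturated chain carbon bound to two aromatic carbons. This is the same kind of change as that from compound 2 to compound 1, but not the same change: in the earlier pair the saturated chain carbon is bound to an aromatic carbon, whereas in compound 4 it is bound to two aromatic carbons. The earlier pair therefore gives a point of comparison only, not a rule.

The step from compound 3 to compound 4 in this assay is expected to be a step that the limit leaves unreadable from compound 3 to compound 4, resting on the measured step of a 1.3-fold lower number from compound 2 to compound 1 (0.11 log units; within the scatter) and on compound 3 standing at the limit > 30 mg/kg. Compound 4 is estimated at 40 mg/kg, with an expected range from 15 mg/kg to 110 mg/kg, and it is expected that this assay may again report only a limit for compound 4.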

Compound 4, dose for half-maximal effect: > 30 mg/kg
Compound 4: only a limit was reported; the forecaster's own chance of this, stated with the estimate: 65%; the middle value lies beyond the limit too.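

In this assay compound 3 and compound 4 both stand at a limit rather than at a number, so no step can be read between them: the limit of > 30 mg/kg in this assay, at which 2 of the 4 values shown sit.

The compounds shown leave open whether methyl in place of hydrogen on a saturated chain carbon bound to two aromatic carbons shifts the dose at all on the core of compound 3, and how far either compound lies past that limit.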